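The source may report more compounds than this note shows. Statements on the series, on what has been measured and on what is new or still open speak of the compounds shown alone.

Working notes on the nitrogen substituent of the shared core. In a functional assay on NCI-H1650 cells (Homo sapiens) for cytotoxicity, read by MTT assay, with a stated time of 72 h (on this read-out lower numbers stand for stronger inhibition and higher numbers for weaker inhibition), compound 1 (`COc1cc(/C=C2\CNC/C(=C\c3cc(OC)c(OC)c(OC)c3)C2=O)cc(OC)c1OC`) gives 4200 nM, compound 2 (`COc1cc(/C=C2\CN(C)C/C(=C\c3cc(OC)c(OC)c(OC)c3)C2=O)cc(OC)c1OC`) gives 1500 nM and compound 3 (`CCN1C/C(=C\c2cc(OC)c(OC)c(OC)c2)C(=O)/C(=C/c2cc(OC)c(OC)c(OC)c2)C1`) gives 8200 nM. Compound 3 therefore sits level with compound 1 within the scatter, and clearly apart from compound 2 only.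

The next structure is compound 4 (`COc1cc(/C=C2\CN(C(=O)CCC(=O)O)C/C(=C\c3cc(OC)c(OC)c(OC)c3)C2=O)cc(OC)c1OC`), with (2-carboxyethyl)carbonyl in place of ethyl on an amine nitrogen in a ring.

For the measured compounds named here, three measured steps bear on this position. They are a 2.8-fold lower number from compound 1 to compound 2 (0.45 log units; beyond the scatter), then a 5.5-fold higher number from compound 2 to compound 3 (0.74 log units; beyond the scatter), which runs the opposite way, and a 2.0-fold higher number from compound 1 to compound 3 (0.29 log units; within the scatter), which stays within the scatter. These steps are modest at most and follow no single direction with substituent size. Going by the values given here, none of them places a carbonyl or a carboxyl-bearing chain on the nitrogen, so the series offers no direct precedent for this change.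

No step beyond the scatter is therefore expected in this assay, though the uncertainty is wide in both directions. The expected change, as an estimate, is a 1.6-fold lower number from compound 3 to compound 4 (0.21 log units; within the scatter). For compound 4 the estimated value is 5000 nM, with an expected range of 1500 nM to 16000 nM.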

Compound 4, half-maximal inhibitory concentration: > 60000 nM
Compound 4: a limit, no number (the forecaster's own chance of this, stated with the estimate: 5%); at least 12-fold (1.07 log units) between middle value and limit.
By their numbers in this assay, from the lowest: compound 2; then compounds 1 and 3 (each within the scatter of the next). At a limit, above all of these: compound 4.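

In this assay compound 4 gives a limit and not a number: the limit of > 60000 nM in this assay, at which 1 of the 4 values shown sits. All three steps onto (2-carboxyethyl)carbonyl run the same way and lie beyond the scatter, namely an at least 7.3-fold higher number from compound 3 to compound 4 (0.86 log units; beyond the scatter), an at least 40-fold higher number from compound 2 to compound 4 (1.60 log units; beyond the scatter) and an at least 14-fold higher number from compound 1 to compound 4 (1.15 log units; beyond the scatter), whereas the exchanges among hydrogen, methyl and ethyl were modest at most and ran in both directions. For the compounds shown here, this position on the amine nitrogen in a ring can therefore carry a large step in this assay, which the earlier compounds did not show, and the new steps give only a lower bound on its size.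

The compounds shown leave open whether the step belongs to the carbonyl on the nitrogen, to the carboxylic acid of the chain, or to the two together. An acetyl group, a methyl ester of the same chain, a longer chain ending in a carboxylic acid and a chain ending in an amine would each bear on that question, and the present values cannot separate these possibilities.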